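Swapping Chloro for Bromo: Expected Effect on Growth Inhibition

The source may hold more compounds than are shown below. What is called first, only, known or untested is meant among the compounds shown, and "the series" means these compounds.

Within the data shown here, compound 2 `COc1ccc(-c2nc3cc(Cl)ccc3s2)cc1OC` provides the only actual number among the values shown, giving 27900 nM in a functional assay on MCF7 cells (Homo sapiens) for antiproliferative activity; a lower number here means a stronger inhibitor of growth, a higher number a weaker inhibitor of growth. Compound 1 `COc1ccc(-c2nc3cc(F)ccc3s2)cc1OC` gives < 0.1 nM in this assay, which is a limit of the assay rather than a number. Among the measured compounds shown here, the single measured step, an at least 270000-fold higher number from compound 1 to compound 2 (5.44 log units; beyond the scatter), is large, but it rests on (the limit of < 0.1 nM in this assay, at which 1 of the 2 values shown sits). Compound 3 `COc1ccc(-c2nc3cc(Br)ccc3s2)cc1OC` differs from compound 2 by bromo in place of chloro on an aromatic carbon. That halogen swap is not the one measured, so the measured step offers no firm guide, and no change beyond the scatter is expected. Compound 3 is therefore expected near 30000 nM, between 5000 nM and 200000 nM, a step of a 1.1-fold higher number from compound 2 to compound 3 (0.03 log units; within the scatter).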

Compound 3, concentration for 50% growth inhibition: 13600 nM
For compound 3 the middle estimate is 2.2-fold (0.34 log units) above the measured one; the range from low to high includes it.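

Two actual numbers can now be compared at this position, and in this assay the swap from chloro to bromo gives a 2.1-fold lower number from compound 2 to compound 3 (0.31 log units; beyond the scatter), a modest change. The gap from fluoro remains far larger, with an at least 130000-fold higher number from compound 1 to compound 3 (5.13 log units; beyond the scatter), so chloro and bromo both stand far from fluoro here. That large step, like the earlier one, rests on a limit rather than a number: the limit of < 0.1 nM in this assay, at which 1 of the 3 values shown sits.

As far as these compounds go, the true size of the fluoro gap stays open. So does how this position would respond to a group other than a halogen, such as an amine or a carboxylic acid.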